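Cyclopentyl to 4-fluorobenzyl on the aromatic nitrogen

The compounds below may be only part of what the source reports. "The series", "measured", "known", "first", "only" and "open" are said of these compounds alone.

The series shares one core and varies the group on an aromatic nitrogen. Compound 1 `COc1ccc([C@@H]2CC(=O)c3c(O)cc(OCc4cn(C5CCCC5)nn4)cc3O2)cc1O` bears cyclopentyl there; in a functional assay on RAW264.7 cells (Mus musculus) for inhibition, read by Griess assay, with stated times of 2 h and 24 h (on this read-out higher numbers stand for weaker inhibition and lower numbers for stronger inhibition), compound 1 gives 10500 nM. Compound 2 `COc1ccc([C@@H]2CC(=O)c3c(O)cc(OCc4cn(Cc5ccc(Cl)cc5)nn4)cc3O2)cc1O` carries 4-chlorobenzyl, and in this assay compound 2 gives 17800 nM. Compound 3 `COc1ccc([C@@H]2CC(=O)c3c(O)cc(OCc4cn(Cc5cccc(C(F)(F)F)c5)nn4)cc3O2)cc1O` carries 3-(trifluoromethyl)benzyl, and in this assay compound 3 gives 19900 nM. Compound 1 thus holds the lowest of the three numbers, but its steps to compound 2 and to compound 3 both lie within the scatter, so no order among the three can be read from them.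

Compound 4 `COc1ccc([C@@H]2CC(=O)c3c(O)cc(OCc4cn(Cc5ccc(F)cc5)nn4)cc3O2)cc1O` is not yet measured. It differs from compound 1 in one place: 4-fluorobenzyl in place of cyclopentyl on an aromatic nitrogen.

For the measured compounds named here, two measured steps bear on this change, both replacing cyclopentyl on the same aromatic nitrogen: a 1.7-fold higher number from compound 1 to compound 2 (0.23 log units; within the scatter) and a 1.9-fold higher number from compound 1 to compound 3 (0.28 log units; within the scatter). Neither moved beyond the scatter. The step of a 1.1-fold higher number from compound 2 to compound 3 (0.05 log units; within the scatter) adds that the choice of group on the saturated chain carbon also left the number essentially unchanged. A third replacement of this kind is therefore expected to behave alike, and the step for compound 4 is estimated as a 1.3-fold higher number from compound 1 to compound 4 (0.12 log units; within the scatter), within the scatter. Compound 4 is expected to give 14000 nM in this assay, with a range from 7000 nM to 30000 nM.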

Compound 4, half-maximal inhibitory concentration: 15100 nM
Compound 4: the middle estimate sits 1.1-fold (0.03 log units) below what was measured; low and high end bracket the measured number.
By their numbers in this assay, from the lowest: compounds 1, 4, 2 and 3 (each within the scatter of the next).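

In this assay, a third benzyl group in place of cyclopentyl on the aromatic nitrogen again stays within the scatter (a 1.4-fold higher number from compound 1 to compound 4 (0.16 log units; within the scatter)), so this position now tolerates a saturated five-membered ring and three differently substituted benzyl groups without a readable difference. The new compound also allows a direct comparison of substituents on the benzyl ring: fluoro in place of chloro on an aromatic carbon (a 1.2-fold lower number from compound 2 to compound 4 (0.07 log units; within the scatter)) and 4-fluorophenyl in place of 3-(trifluoromethyl)phenyl (a 1.3-fold lower number from compound 3 to compound 4 (0.12 log units; within the scatter)) are both within the scatter, so all the steps among these four compounds are flat and neither halogen nor trifluoromethyl can be told apart here. No measurement at hand offers an explanation for this flat picture.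

Still open, going by these compounds, is whether an amine or a carboxylic acid on the benzyl ring, or a longer chain in place of the benzyl group, would move the number beyond the scatter. Also open, on these data alone, is whether unsubstituted benzyl or a small group such as methyl on this nitrogen would fit the same flat picture.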